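The compounds below may be only part of what the source reports. "The series", "measured", "known", "first", "only" and "open" are said of these compounds alone.

Of the compounds shown here, three sharing one core have been measured in a functional assay on ileum (strain Hartley) for agonist activity at 5-hydroxytryptamine receptor 3A (Cavia porcellus); a lower number here means a less potent compound, a higher number a more potent compound, by a factor of ten per unit of this negative logarithm. Compound 1 `CN1CCN(c2nc3cc([N+](=O)[O-])ccc3o2)CC1` gives 6.1, the lowest of the three numbers. Compound 3 `CN1CCN(c2nc3cc(Cl)cc(Cl)c3o2)CC1` gives 6.51, and compound 2 `Cc1cc(Cl)cc2nc(N3CCN(C)CC3)oc12` gives 6.7; each of these lies beyond the scatter above compound 1. Within the data shown here, the only step between two measured compounds that differ in one place is a number 0.19 log units lower from compound 2 to compound 3 (within the scatter), and it stays within the scatter. Compound 4 `CN1CCN(c2nc3cc(N)ccc3o2)CC1` differs from compound 1 by amino in place of nitro on an aromatic carbon. No measured step replaces the nitro group, so nothing among these compounds points to a change in either direction. Compound 4 is therefore expected to give about 6.2 in this assay, within a range from 5.4 to 7, an estimated step of a number 0.10 log units higher from compound 1 to compound 4 (within the scatter).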

Compound 4, negative logarithm of the half-maximal effective concentration: 4.97
Compound 4: middle estimate off by 1.23 log units, on the high side; measured number outside the range, below it.
By their numbers in this assay, from the lowest: compound 4; then compound 1; then compounds 3 and 2 (each within the scatter of the next).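

In this assay, among these compounds, amino in place of nitro on this aromatic carbon gives a number 1.13 log units lower from compound 1 to compound 4 (beyond the scatter), so a single group at this position can shift the number well beyond the scatter, unlike the one earlier step, chloro in place of methyl. Nitro is thus far from interchangeable with amino here. Nothing available explains the drop. Still open, going by these compounds, is whether amino lowers the number or nitro raises it. A plain hydrogen, a methoxy group or an acetamide at this position would help separate the two.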